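Removing the methylamino group from compound 1

A few compounds are considered here, and "the series" means these few. Any claim that something is new, unique, unknown or untested is made for them only; others in the source may bear on it.

Measured compounds:
- compound 1, `CNc1cc(C(N)=O)ccc1-n1nc(C(C)C)c2c(-n3cnc(-c4cnn(C)c4)c3)ccnc21`: 419 nM
- compound 2, `CC(C)c1nn(-c2ccc(C(N)=O)c(N[C@H]3CC[C@H](O)CC3)c2)c2nccc(-n3cnc(-c4ccc(Oc5ccccc5)cc4)c3)c12`: 503 nM
- compound 3, `COc1cncc(-c2ccnc3c2c(C(C)C)nn3-c2ccc(C(N)=O)c(N[C@H]3CC[C@H](O)CC3)c2)c1`: 451 nM

All three were tested in a functional assay on SK-BR-3 cells (Homo sapiens) for inhibition, read by CellTiter-Glo, with a stated time of 72 h; on this read-out higher numbers stand for weaker inhibition and lower numbers for stronger inhibition. Compound 1 gives 419 nM, the lowest of the three numbers, but its gap to compound 3 and to compound 2 lies within the scatter of repeated measurements, so the three compounds cannot be told apart on these numbers.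

Compound 4, `CC(C)c1nn(-c2ccc(C(N)=O)cc2)c2nccc(-n3cnc(-c4cnn(C)c4)c3)c12`, has not been measured yet. It differs from compound 1 in one place: hydrogen in place of methylamino on an aromatic carbon. Going by the values given here, compounds 2 and 3 carry a different amino substituent at this same place, and no compound with a bare hydrogen there has been measured, so the data hold no direct comparison for this change.

Without such a comparison, the step is expected to be modest, in the direction of a weaker result in this assay, possibly not beyond the scatter. For compound 4 the expected outcome is 900 nM, with a range from 300 nM to 3000 nM. This estimate means a step of a 2.1-fold higher number from compound 1 to compound 4 (0.33 log units; beyond the scatter).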

Compound 4, half-maximal inhibitory concentration in the SK-BR-3 assay: 1640 nM
Estimate against measurement, compound 4: 1.8-fold (0.26 log units) below; low and high end bracket the measured number.
By their numbers in the SK-BR-3 assay, from the lowest: compounds 1, 3 and 2 (each within the scatter of the next); then compound 4.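

The earlier compounds shown here all carried an amino substituent at this place on the aromatic ring, so they could not show whether that substituent matters at all. Compound 4 supplies the missing comparison: in the SK-BR-3 assay, replacing methylamino with hydrogen gives a 3.9-fold higher number from compound 1 to compound 4 (0.59 log units; beyond the scatter), so on this core the methylamino group contributes to the cell result, though the step is modest. In a physicochemical assay for lipophilicity, read by HPLC, measured as octanol-water partition, at pH 7.4 (on this read-out lower numbers stand for lower lipophilicity and higher numbers for higher lipophilicity), compound 1 gives 1.9 and compound 4 gives 3. The loss of inhibition comes with a rise in lipophilicity, as the physicochemical assay shows, so greater lipophilicity did not bring stronger inhibition in this pair: the measured distribution coefficient of compound 1, 1.9, and of compound 4, 3, a number 1.10 log units higher (beyond the scatter)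

The compounds shown leave open whether the benefit depends on the nitrogen and its hydrogen, or whether other small groups on this carbon would serve equally well; a methoxy or dimethylamino group there would help separate these possibilities. Going by these compounds, it also remains open how the larger amino substituent of compound 2 and compound 3 compares with methylamino, as those compounds also differ from compound 1 elsewhere in the structure.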